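Acyl urea series: solubility outlook for a trifluoroethoxy analogue

The compounds below may be only part of what the source reports. "The series", "measured", "known", "first", "only" and "open" are said of these compounds alone.

Among the measured compounds shown here, compound 1 `COc1ccccc1C(=O)NC(=O)Nc1ccc(-c2ccccn2)c(C(F)(F)F)c1` holds the higher of the two numbers measured so far. In a physicochemical assay for solubility, in phosphate buffer, at pH 7.4 (on this read-out higher numbers stand for higher solubility and lower numbers for lower solubility), compound 1 gives 19 ug/mL, while compound 2 `COc1ccncc1C(=O)NC(=O)Nc1ccc(-c2ccccc2)c(C(F)(F)F)c1` gives 6.6 ug/mL, a gap beyond the usual scatter. The two compounds differ in more than one place, so no single step can be read from that pair.

Compound 3 `COc1ccccc1C(=O)NC(=O)Nc1ccc(OCC(F)(F)F)c(C(F)(F)F)c1` is not yet measured. Relative to compound 1 the change is 2,2,2-trifluoroethoxy in place of pyridin-2-yl on an aromatic carbon, on the ring that carries the trifluoromethyl group, at the position para to the large group. For the measured compounds named here, no measured pair in the set isolates this change, so there is no step from which its effect could be read directly. The expectation is a modest downward step a 1.9-fold lower number from compound 1 to compound 3 (0.28 log units; within the scatter), of a size close to the edge of the scatter rather than clearly beyond it. Compound 3 is therefore estimated at 10 ug/mL, with a range from 3 ug/mL to 30 ug/mL.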

Compound 3, solubility: < 1 ug/mL
Compound 3 was reported as a limit; the forecaster's own chance of this, stated with the estimate: 5%; at least 10-fold (1.00 log units) between middle value and limit.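

Among the compounds shown here, replacing pyridin-2-yl with 2,2,2-trifluoroethoxy on this aromatic carbon, ortho to a trifluoromethyl group, gives in this assay an at least 19-fold lower number from compound 1 to compound 3 (1.27 log units; beyond the scatter), the one step that can be read at this position. The two groups match in their counts of heavy atoms, hydrogen-bond donors and hydrogen-bond acceptors and carry no net charge, so those counts do not track this large step, while the leaving group has a six-membered aromatic ring and the entering group has none. For compound 3 the reading of < 1 ug/mL is a limit of the assay and not a number, so the full size of the step stays unknown: the limit of < 1 ug/mL in this assay, at which 1 of the 3 values shown sits.

Going by these compounds, whether the step follows the loss of the ring or the arrival of the fluorinated chain stays open. Also open, on these data alone, is what a morpholine or a carboxylic acid on this carbon would give.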